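Swapping Chlorine for Methyl on the Aryl Ether

The source may hold more compounds than are shown below. What is called first, only, known or untested is meant among the compounds shown, and "the series" means these compounds.

Among the three measured compounds, compound 3 `Cc1c(F)c(Oc2cccc(C(=N)N)c2)nc(Oc2ccc(Cl)c(N(C)C)c2)c1F` holds the only actual number: in an assay on isolated protein for inhibition of serine protease 1 (Bos taurus) (on this read-out lower numbers stand for stronger inhibition and higher numbers for weaker inhibition), compound 3 gives 1000 nM. Compound 1 `Cc1c(F)c(Oc2cccc(N)c2)nc(Oc2cccc(C(=N)N)c2)c1F` reaches only a limit of the assay, giving > 5000 nM in this assay. Compound 2 `Cc1c(F)c(Oc2cccc(CC(N)=O)c2)nc(Oc2cccc(C(=N)N)c2)c1F` likewise stops at a limit, giving > 5000 nM in this assay. Because both sit at the limit of > 5000 nM in this assay, at which 2 of the 3 values shown sit, the steps of an at least 5.0-fold lower number from compound 1 to compound 3 (0.69 log units; beyond the scatter) and an at least 5.0-fold lower number from compound 2 to compound 3 (0.69 log units; beyond the scatter) can be read only as lower bounds, and a step that the two limits leave unreadable from compound 1 to compound 2 cannot be read at all. Compound 4 `Cc1ccc(N(C)C)cc1Oc1nc(Oc2cccc(C(=N)N)c2)c(F)c(C)c1F` alters the aryl ether: 5-(dimethylamino)-2-methylphenyl in place of 4-chloro-3-(dimethylamino)phenyl on an oxygen on an aromatic ring. Within the data shown here, no measured step touches this particular exchange; the two readable steps replace the whole 4-chloro-3-(dimethylamino)phenyl ring at once, and neither tells how the chlorine or the methyl contributes on its own. The dimethylamino group stays in place. Compound 4 is therefore expected to shift only modestly, by a step of a 1.5-fold higher number from compound 3 to compound 4 (0.18 log units; within the scatter) in this assay. Compound 4 is estimated at 1500 nM, between 400 nM and 6000 nM.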

Compound 4, inhibition constant: > 5000 nM
Compound 4: a limit, no number; the forecaster's own chance of this, stated with the estimate: 25%; at least 3.3-fold (0.52 log units) between middle value and limit.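

With a dimethylamino group present on both rings, 5-(dimethylamino)-2-methylphenyl in place of 4-chloro-3-(dimethylamino)phenyl gives an at least 5.0-fold higher number from compound 3 to compound 4 (0.69 log units; beyond the scatter) in this assay. Among these compounds, a dimethylamino group on the aryl ether is therefore not enough on its own to keep compound 4 within the measurable range, and compound 3 remains the only compound here with a number. The step is only a lower bound and the steps from compound 1 and compound 2 to compound 4 cannot be read, because compound 4 gives only a limit: the limit of > 5000 nM in this assay, at which 3 of the 4 values shown sit.

On these data alone, it remains open whether the change comes from methyl replacing chlorine or from the different placement of the groups named in the two rings. Also open, as far as these compounds go, is how a bromine, a methoxy group or a nitrile would behave in place of the chlorine.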